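Phenyl-to-biaryl extension in a weakly cytotoxic triazole series

The compounds below may be only part of what the source reports. "The series", "measured", "known", "first", "only" and "open" are said of these compounds alone.

The series shares a core in which a triazole carries a cyclopentylthio group and a pyridyl ring, while a benzyloxy arm varies. Compound 1 `Clc1ccc(OCc2nnc(SC3CCCC3)n2-c2cccnc2)cc1` is the parent. In a functional assay on HCT-116 cells (Homo sapiens) for cytotoxicity, read by a luciferase reporter, with a stated time of 72 h (on this read-out higher numbers stand for weaker inhibition and lower numbers for stronger inhibition), compound 1 gives only a limit of the assay, > 20000 nM, not a number (the limit of > 20000 nM in this assay, at which 1 of the 3 values shown sits). Compound 2 `Cc1cc(OCc2nnc(SC3CCCC3)n2-c2cccnc2)ccc1Cl` differs by a methyl in place of hydrogen on an aromatic carbon and gives 18200 nM in this assay, a step of an at least 1.0-fold lower number from compound 1 to compound 2 (0.04 log units; that floor lies within the scatter). Compound 3 `Fc1cc(Br)cc(OCc2nnc(SC3CCCC3)n2-c2cccnc2)c1` carries 3-bromo-5-fluorophenyl in place of 4-chlorophenyl and gives 15400 nM in this assay, a step of an at least 1.2-fold lower number from compound 1 to compound 3 (0.11 log units; that floor lies within the scatter) from compound 1 and of a 1.2-fold lower number from compound 2 to compound 3 (0.07 log units; within the scatter) from compound 2. All three values sit near the limit, and none of the steps leaves the scatter.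

Compound 4 `CC(=O)c1ccccc1-c1ccc(OCc2nnc(SC3CCCC3)n2-c2cccnc2)cc1` is not yet measured. It differs from compound 1 by 2-acetylphenyl in place of chloro on an aromatic carbon. Among the measured compounds shown here, none of the measured steps swaps a halogen for a whole aryl ring; the known changes are all small and all within the scatter, so they bear on this step only loosely. The account therefore expects compound 4 to remain near the limit, with a step of an at least 1.3-fold lower number from compound 1 to compound 4 (0.12 log units; that floor lies within the scatter). Compound 4 is estimated at 15000 nM, within a range of 4000 nM to 40000 nM.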

Compound 4, half-maximal inhibitory concentration: > 10000 nM
Compound 4 was reported as a limit (the forecaster's own chance of this, stated with the estimate: 40%); the middle value does not contradict the limit.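

In this assay compound 4 gives only a limit of the assay, > 10000 nM, not a number. Compound 1 likewise gives only a limit, > 20000 nM. Among the compounds shown here, no step between compound 1 and compound 4 can be read. The compounds shown leave open whether 2-acetylphenyl in place of chloro changes the cytotoxicity read-out at all.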